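The compounds below may be only part of what the source reports. "The series", "measured", "known", "first", "only" and "open" are said of these compounds alone.

In a functional assay on A549 cells (Homo sapiens) for antiproliferative activity, read by MTT assay, with a stated time of 48 h (a lower number here means a stronger inhibitor, a higher number a weaker inhibitor), compound 2 `CCCCOc1ccc(C(=O)/C=C/c2c(/C=C/c3ccc(OC)cc3)cc(OC)cc2OC)cc1` gives 8.7 ug/mL. For the measured compounds named here, its only measured neighbour, compound 1 `COc1ccc(/C=C/c2cc(OC)cc(OC)c2/C=C/C(=O)c2cccc(OC)c2)cc1`, gives 6.1 ug/mL, so these two values lie within the scatter of each other and cannot be ranked. The next compound to consider is compound 3 `COc1ccc(/C=C/c2cc(OC)cc(OC)c2/C=C/C(=O)c2cccc(Br)c2)cc1`, which has not yet been measured. On a carbonyl carbon, it has 3-bromophenyl in place of the 4-butoxyphenyl of compound 2: 3-bromophenyl in place of 4-butoxyphenyl on a carbonyl carbon. Going by the values given here, only one measured step bears on this place: a 1.4-fold higher number from compound 1 to compound 2 (0.15 log units; within the scatter), which exchanges 3-methoxyphenyl for 4-butoxyphenyl and stays within the scatter. Among the compounds with values here, no measured compound carries 3-bromophenyl, so this single step is thin evidence and leaves the effect of the new group unknown. Even so, the one change seen here did not move the number beyond the scatter, so no step beyond the scatter is expected in this assay, and no firm direction can be expected. The estimate amounts to a 1.2-fold lower number from compound 2 to compound 3 (0.06 log units; within the scatter). The expected value for compound 3 is 7.5 ug/mL, with an estimated range from 3 ug/mL to 17 ug/mL.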

Compound 3, half-maximal inhibitory concentration: 8.1 ug/mL
Compound 3: middle estimate off by 1.1-fold (0.03 log units), on the low side, within the range that was stated.
By their numbers in this assay, from the lowest: compounds 1, 3 and 2 (each within the scatter of the next).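

In this assay, the group on the carbonyl carbon now differs in two further ways, and neither step separates the compounds (a 1.1-fold lower number from compound 2 to compound 3 (0.03 log units; within the scatter); a 1.3-fold higher number from compound 1 to compound 3 (0.12 log units; within the scatter)). The first of these steps replaces 4-butoxyphenyl, with its oxygen and its chain, by the smaller 3-bromophenyl, while the second puts bromo in place of methoxy on an aromatic carbon, so among these three compounds, groups that differ clearly in size and in atoms give values that cannot be ranked. No measurement is at hand that could explain this lack of separation.

From the compounds shown here alone, all three groups at this place are substituted phenyl rings, so it remains open whether the same holds for a group without such a ring, such as an amine, a carboxylic acid or a plain alkyl chain. It also remains open whether any change at this place can move the number beyond the scatter, or whether differences among these compounds would appear only through changes elsewhere on the shared core.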